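The source may report more compounds than this note shows. Statements on the series, on what has been measured and on what is new or still open speak of the compounds shown alone.

Among the compounds with values here, compound 1 `C=CC1C(=O)N(c2cc(OC)c(OC)c(OC)c2)C1c1ccc(OC)cc1` is one of two compounds measured in a functional assay on MCF7 cells (Homo sapiens) for inhibition, read by resazurin assay, with a stated time of 72 h; on this read-out lower numbers stand for stronger inhibition and higher numbers for weaker inhibition; in that assay compound 1 gives 17 nM, the lower of the two numbers. Within the data shown here, its companion, compound 2 `COc1ccc(C2C(C3CC3)C(=O)N2c2cc(OC)c(OC)c(OC)c2)cc1`, gives 120 nM, and the only measured step, a 7.1-fold higher number from compound 1 to compound 2 (0.85 log units; beyond the scatter), follows a change on a saturated ring carbon of the shared core.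

Compound 3 `C=CC1C(=O)N(c2cc(OC)c(OC)c(OC)c2)C1c1ccc(SC)cc1` differs from compound 1 elsewhere: methylsulfanyl in place of methoxy on an aromatic carbon. Among the measured compounds shown here, no measured step touches this aromatic position, so the step to compound 2 says nothing direct about it; the change keeps the size of the group and its count of acceptors, so little movement beyond the scatter is expected. The step from compound 1 to compound 3 in this assay is therefore expected to be small, a 1.8-fold higher number from compound 1 to compound 3 (0.25 log units; within the scatter), with a slight lean toward a higher number. Compound 3 is expected to give about 30 nM, within 10 nM to 90 nM.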

Compound 3, half-maximal inhibitory concentration: 51 nM
Beside the measured number, compound 3's estimate is 1.7-fold (0.23 log units) below it; the range from low to high includes it.
By their numbers in this assay, from the lowest: compound 1; then compound 3; then compound 2.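

The aromatic position had not been touched by any earlier step, and it proves sensitive: methylsulfanyl in place of methoxy gives a 3.0-fold higher number from compound 1 to compound 3 (0.48 log units; beyond the scatter) in this assay and so moves the number beyond the scatter. The 4-methoxyphenyl group of compound 1 therefore cannot be exchanged for 4-(methylsulfanyl)phenyl without a measurable loss of inhibition, even though the two groups have the same heavy-atom and hydrogen-bond acceptor counts and differ by oxygen against sulfur. No evidence at hand accounts for this loss.

Going by these compounds, it remains open how other groups would fare at this place, such as an ethoxy group, a chlorine atom or a dimethylamino group. On these data alone, it is also open whether the same exchange would give a similar step with the cyclopropyl group of compound 2 in place of vinyl.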